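A few compounds are considered here, and "the series" means these few. Any claim that something is new, unique, unknown or untested is made for them only; others in the source may bear on it.

Of the compounds shown here, three with a shared core have been tested in a functional assay on MDA-MB-231 cells (Homo sapiens) for antiproliferative activity, read by MTT assay, with a stated time of 48 h; on this read-out higher numbers stand for weaker inhibition and lower numbers for stronger inhibition. Compound 1 `CCOC(=O)CN(Cc1ccccc1)c1nc(Nc2ccc(Cl)cc2)ncc1[N+](=O)[O-]` carries a 4-chlorophenyl group on a nitrogen on an aromatic ring, and in this assay compound 1 gives 34400 nM. Compound 2 `CCOC(=O)CN(Cc1ccccc1)c1nc(NCc2ccccc2)ncc1[N+](=O)[O-]` carries a benzyl group at that position instead, and compound 2 gives 82400 nM. Compound 3 `CCOC(=O)CNc1nc(NCc2ccccc2)ncc1[N+](=O)[O-]` has a hydrogen in place of a second benzyl group elsewhere on the core, and compound 3 gives 22300 nM. Among these three numbers, compound 2 stands highest, that is, it is the weakest inhibitor of the three.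

Compound 4 `CCOC(=O)CN(Cc1ccccc1)c1nc(Nc2cccc(OC)c2)ncc1[N+](=O)[O-]` has not yet been measured. It differs from compound 2 in one place: 3-methoxyphenyl in place of benzyl on a nitrogen on an aromatic ring.

The step that bears most directly on this change runs the other way, from an aromatic ring to a benzyl group: a 2.4-fold higher number from compound 1 to compound 2 (0.38 log units; beyond the scatter). Reversing that direction, a return to an aromatic group on this nitrogen would be expected to bring a modestly lower number. The step of a 3.7-fold lower number from compound 2 to compound 3 (0.57 log units; beyond the scatter) concerns a different position and informs this change only loosely.

Compound 4 is therefore expected to give about 30000 nM, with a likely range from 10000 nM to 80000 nM. This estimate corresponds to an expected step of a 2.7-fold lower number from compound 2 to compound 4 (0.44 log units; beyond the scatter).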

Compound 4, half-maximal inhibitory concentration: 47200 nM
Estimate against measurement, compound 4: 1.6-fold (0.20 log units) below; low and high end bracket the measured number.
By their numbers in this assay, from the lowest: compounds 3, 1, 4 and 2 (each within the scatter of the next, the first and the last beyond it).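

In this assay, replacing benzyl with 3-methoxyphenyl on this nitrogen gives a 1.7-fold lower number from compound 2 to compound 4 (0.24 log units; within the scatter), a step within the scatter, whereas the earlier step of a 2.4-fold higher number from compound 1 to compound 2 (0.38 log units; beyond the scatter), between 4-chlorophenyl and benzyl, lay beyond it. The two groups that place a benzene ring straight on the amino nitrogen also cannot be told apart, with a 1.4-fold higher number from compound 1 to compound 4 (0.14 log units; within the scatter) again within the scatter, so compound 4 falls within the scatter of both compound 1 and compound 2, and the earlier gap cannot be read as a general difference between such groups and benzyl. No measurement is available here that would explain this result.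

The compounds shown leave open whether a longer chain, such as phenethyl, or a simple amine such as morpholine at this position would shift the number beyond the scatter. They also leave open whether 3-methoxyphenyl would behave the same way on a compound with hydrogen in place of the other benzyl group, or whether a carboxylic acid in place of the ethyl ester would change the picture.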